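A few compounds are considered here, and "the series" means these few. Any claim that something is new, unique, unknown or untested is made for them only; others in the source may bear on it.

Measured so far:
- compound 1, `C=C(CC)C(=O)c1ccc(OCC(=O)Nc2ccc3nc[nH]c3c2)c(Cl)c1Cl`: 3200 nM
- compound 2, `C=C(CC)C(=O)c1ccc(OCC(=O)Nc2ccc3c(c2)C(O)N=NC3O)c(Cl)c1Cl`: 8500 nM

In a functional assay on CLL cells (Homo sapiens) for cytotoxicity, read by MTT assay, with a stated time of 48 h (on this read-out higher numbers stand for an effect only at larger amounts of compound and lower numbers for an effect already at smaller amounts), compound 1 gives the lower of the two numbers. Compound 2 gives a higher number in this assay, and the gap between the two values lies beyond the scatter of repeated measurements. Among the compounds with values here, no step between compounds differing in a single place is available, so the effect of any one change on this assay is not known from these two compounds alone.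

Compound 3, `C=C(CC)C(=O)c1ccc(OCC(=O)Nc2ccc(C(C)=O)cc2)c(Cl)c1Cl`, has not yet been measured. It differs from compound 1 at one place: 4-acetylphenyl in place of 1H-benzimidazol-6-yl on an amide-type nitrogen. Within the data shown here, with no measured step of this kind to draw on, the size of the change is uncertain, and a step within the scatter, or a small move toward a higher number, is expected. Compound 3 is estimated at 4500 nM in this assay, within a range from 1500 nM to 15000 nM. This estimate means an expected step of a 1.4-fold higher number from compound 1 to compound 3 (0.15 log units; within the scatter).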

Compound 3, half-maximal effective concentration: 3900 nM
Compound 3: the middle estimate sits 1.2-fold (0.06 log units) above what was measured, within the range that was stated.
By their numbers in this assay, from the lowest: compounds 1 and 3 (each within the scatter of the next); then compound 2.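

In this assay, 4-acetylphenyl in place of 1H-benzimidazol-6-yl on the amide-type nitrogen gives a 1.2-fold higher number from compound 1 to compound 3 (0.09 log units; within the scatter), so this exchange of one group for another leaves no readable difference. The entering group has no hydrogen-bond donor and no ring nitrogen, which shows that, for this pair, neither feature of 1H-benzimidazol-6-yl is needed to keep the number at this level. Nothing measured on these compounds explains why the two groups read alike.

Going by these compounds, it remains open how a plain phenyl, or a phenyl carrying an amine or a carboxylic acid instead of the acetyl group, would read in this assay. On these data alone, it also remains open whether this equivalence of the two groups would hold with any other part of the core of compound 1 changed.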